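Closing the Urea Side Chain into a Ring

This account rests on a few compounds, and the source may have more. Where it says the series, first, only, none or still open, it means among the compounds named here.

Compound 1 `COCCCNC(=O)Nc1cc2c(Nc3ccc(F)c(Cl)c3)ncnc2cc1O[C@H]1CCOC1` gives 4100 nM in a functional assay on A-431 cells (Homo sapiens) for antiproliferative activity, read by sulforhodamine B assay, with a stated time of 72 h; on this read-out higher numbers stand for weaker inhibition and lower numbers for stronger inhibition.
Compound 2 `CN(C)CCN(C)C(=O)Nc1cc2c(Nc3ccc(F)c(Cl)c3)ncnc2cc1O[C@H]1CCOC1` gives 450 nM in this assay.

Of these two numbers, compound 2 holds the lower one, and the gap to compound 1 is the step of a 9.1-fold lower number from compound 1 to compound 2 (0.96 log units; beyond the scatter). Compound 3 `CN1CCN(C(=O)Nc2cc3c(Nc4ccc(F)c(Cl)c4)ncnc3cc2O[C@H]2CCOC2)CC1` is the next member of the series, and its difference from compound 2 is 4-methylpiperazin-1-yl in place of (2-(dimethylamino)ethyl)(methyl)amino on a carbonyl carbon. For the measured compounds named here, the one measured step, a 9.1-fold lower number from compound 1 to compound 2 (0.96 log units; beyond the scatter), concerns the same carbonyl carbon, but there the group that entered was the very group that now leaves, so it offers only indirect guidance. The leaving and entering groups of the new change match each other in the counts given above, differing mainly in that one is a chain and the other a ring. The step of a 1.1-fold higher number from compound 2 to compound 3 (0.05 log units; within the scatter) is therefore expected to be small, with no clear direction beyond the scatter. Compound 3 is estimated at 500 nM, within a range from 180 nM to 1500 nM.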

Compound 3, half-maximal inhibitory concentration: 675 nM
For compound 3 the middle estimate is 1.4-fold (0.13 log units) below the measured one; the measured number falls inside the stated range.
By their numbers in this assay, from the lowest: compounds 2 and 3 (each within the scatter of the next); then compound 1.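

Compound 3 shows that on this carbonyl carbon, the open (2-(dimethylamino)ethyl)(methyl)amino chain can be tied into the 4-methylpiperazin-1-yl ring with no change beyond the scatter in this assay (a 1.5-fold higher number from compound 2 to compound 3 (0.18 log units; within the scatter)). The ring also stays clearly ahead of the (3-methoxypropyl)amino group (a 6.1-fold lower number from compound 1 to compound 3 (0.78 log units; beyond the scatter)), so the advantage seen with compound 2 does not depend on an open chain. Nothing measured here explains these numbers.

Going by these compounds, it remains open whether the ring's second nitrogen matters, which a morpholine ring, with oxygen at that place, or a piperidine ring, with carbon there, could test. On these data alone, it is equally open whether ring size matters, as a seven-membered homopiperazine ring would show.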